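Replacing Azidomethyl with Dimethylcarbamoyl on the Shared Core

The source may hold more compounds than are shown below. What is called first, only, known or untested is meant among the compounds shown, and "the series" means these compounds.

In a functional assay on MCF7 cells (Homo sapiens) for antiproliferative activity, read by MTT assay, with a stated time of 48 h (a lower number here means a stronger inhibitor, a higher number a weaker inhibitor), compound 1 (`CC(C)=CCC[C@]1(C)/C=C/[C@@H](OC(=O)C=C(C)C)[C@](C)(O)/C=C/C(=O)/C(CN(C)C)=C\C1`) gives 690 nM as its value. Compound 2 (`CC(C)=CCC[C@]1(C)/C=C/[C@@H](OC(=O)C=C(C)C)[C@](C)(O)/C=C/C(=O)/C(CN=[N+]=[N-])=C\C1`) gives 4890 nM and holds the higher of the two numbers, making it the weaker inhibitor of the pair. Going by the values given here, the single measured step, a 7.1-fold higher number from compound 1 to compound 2 (0.85 log units; beyond the scatter), comes with azido in place of dimethylamino on a saturated chain carbon bound to a double-bonded ring carbon.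

The next compound, compound 3 (`CC(C)=CCC[C@]1(C)/C=C/[C@@H](OC(=O)C=C(C)C)[C@](C)(O)/C=C/C(=O)/C(C(=O)N(C)C)=C\C1`), carries dimethylcarbamoyl in place of azidomethyl on a double-bonded ring carbon. It restores the dimethylamino nitrogen of compound 1, which stands at 690 nM in this comparison, but joins that nitrogen to a carbonyl. Among the compounds with values here, no measured compound has this arrangement, so the step from compound 1 to compound 2 bears on the change only in part, and recovery of its full size is not expected. The expected move in this assay is small and leans toward a lower number, with a 1.6-fold lower number from compound 2 to compound 3 (0.21 log units; within the scatter) as the estimate, not beyond the scatter. For compound 3 the estimated value is 3000 nM with an expected range from 800 nM to 10000 nM in this assay.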

Compound 3, half-maximal inhibitory concentration: 3670 nM
The estimate for compound 3 lay 1.2-fold (0.09 log units) below the measured number, within the range that was stated.
By their numbers in this assay, from the lowest: compound 1; then compounds 3 and 2 (each within the scatter of the next).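

In this assay, the two groups on this double-bonded ring carbon that carry no saturated chain carbon to a dimethylamino nitrogen cannot be told apart, with a 1.3-fold lower number from compound 2 to compound 3 (0.12 log units; within the scatter) and thus no order between azidomethyl and dimethylcarbamoyl. The other new step, a 5.3-fold higher number from compound 1 to compound 3 (0.73 log units; beyond the scatter), shows that a dimethylamino nitrogen is not enough on its own to bring back the number of compound 1 when it sits on a carbonyl, so compound 1, with (dimethylamino)methyl, is the only one of the three set apart, and it stands as the strongest of them. The data shown offer no measurement that accounts for this difference.

The compounds shown leave open whether another amine held on the same saturated chain carbon, such as a pyrrolidine, a morpholine or a primary amine, would stand with compound 1 or with compounds 2 and 3. They also leave open what a longer chain ending in dimethylamino, or a carboxylic acid at this place, would give in this assay on the shared core.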